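This account rests on a few compounds, and the source may have more. Where it says the series, first, only, none or still open, it means among the compounds named here.

In an in vitro ADME assay on microsomes from liver (Homo sapiens) for pharmacokinetics, read by LC-MS (a higher number here means faster removal of the compound, a lower number slower removal), compound 1 `Cc1ccc2nc(C)n(-c3ccc(C(=O)NC4CC4)s3)c2c1` gives 10 mL/min/kg and compound 2 `Cc1nc2ccc(C(F)(F)F)cc2n1-c1ccc(C(=O)NC2CC2)s1` gives 8 mL/min/kg, so compound 2 stands level with compound 1 within the scatter. Compound 3 `Cc1nc2ccc(F)cc2n1-c1ccc(C(=O)NC2CC2)s1` differs from compound 2 by fluoro in place of trifluoromethyl on an aromatic carbon, which puts fluoro in place of trifluoromethyl on an aromatic carbon. For the measured compounds named here, the one measured step that bears on this, a 1.3-fold lower number from compound 1 to compound 2 (0.10 log units; within the scatter), exchanged methyl for trifluoromethyl on an aromatic carbon. A step beyond the scatter is therefore not expected in this assay, and the expected size is a 1.1-fold higher number from compound 2 to compound 3 (0.05 log units; within the scatter). For compound 3 the estimated clearance is 9 mL/min/kg, with an expected range of 5 mL/min/kg to 16 mL/min/kg.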

Compound 3, clearance: < 4 mL/min/kg
Compound 3: a limit, no number (the forecaster's own chance of this, stated with the estimate: 5%); at least 2.2-fold (0.35 log units) between middle value and limit.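

For the compounds shown here, at this position, on the six-membered aromatic ring, fluoro separates compound 3 from the earlier compounds in this assay: compound 3 gives < 4 mL/min/kg, which is a limit of the assay and not a number. Against methyl, the change gives an at least 2.5-fold lower number from compound 1 to compound 3 (0.39 log units; beyond the scatter), the first step here to pass the scatter. Against trifluoromethyl, it gives an at least 2.0-fold lower number from compound 2 to compound 3 (0.30 log units; that floor lies within the scatter).

As far as these compounds go, the full size of both steps stays open: the limit of < 4 mL/min/kg in this assay, at which 1 of the 3 values shown sits. Also open is whether chloro, methoxy or nitrile at this position would give a comparably low clearance.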